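Hydroxymethyl versus ethoxycarbonyl on the pyrazole-bearing core

A few compounds are considered here, and "the series" means these few. Any claim that something is new, unique, unknown or untested is made for them only; others in the source may bear on it.

Measured so far:
compound 1 `C/C=C/C(=O)Nc1cccc(Cn2nc(-c3ccc(Oc4ccccc4)cc3)cc2CO)c1`: 22600 nM
compound 2 `C=CC(=O)Nc1cccc(Cn2nc(-c3ccc(Oc4ccccc4)cc3)cc2C(=O)OCC)c1`: 7600 nM

In a functional assay on JeKo-1 cells (Homo sapiens) for inhibition, read by luminescence and CellTiter-Glo, with a stated time of 72 h (on this read-out higher numbers stand for weaker inhibition and lower numbers for stronger inhibition), compound 2 gives 7600 nM, the lowest of the two numbers seen, and compound 1 gives 22600 nM, a number beyond the usual scatter from that of compound 2. The two differ in two places at once, so their gap cannot be pinned on a single change.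

Compound 3 `C=CC(=O)Nc1cccc(Cn2nc(-c3ccc(Oc4ccccc4)cc3)cc2CO)c1` keeps the acrylamide of compound 2 and changes only one place: hydroxymethyl in place of ethoxycarbonyl on an aromatic carbon. Going by the values given here, no pair that differs only in this way has been measured; compound 1 carries the same hydroxymethyl but a different amide, so it offers only an indirect hint. The step of a 1.4-fold higher number from compound 2 to compound 3 (0.16 log units; within the scatter) is expected to be small, toward weaker inhibition if anything. Compound 3 is estimated at 11000 nM, within 3500 nM to 35000 nM.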

Compound 3, half-maximal inhibitory concentration: 5200 nM
For compound 3 the middle estimate is 2.1-fold (0.33 log units) above the measured one, within the range that was stated.
By their numbers in this assay, from the lowest: compounds 3 and 2 (each within the scatter of the next); then compound 1.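

In this assay the direct comparison at this aromatic carbon, hydroxymethyl in place of ethoxycarbonyl, gives a 1.5-fold lower number from compound 2 to compound 3 (0.16 log units; within the scatter) and so does not separate the two groups, even though they differ in size and in hydrogen-bond donors. With hydroxymethyl held fixed, the amide can now be compared on its own: vinyl in place of prop-1-en-1-yl on the carbonyl carbon gives a 4.3-fold lower number from compound 1 to compound 3 (0.64 log units; beyond the scatter) as a modest step. Going by these compounds alone, of these two single changes, only the one at the amide lies beyond the scatter.

Still open, from the compounds shown here alone, is whether an amine, a carboxylic acid or a longer chain such as hydroxypropyl on this aromatic carbon would also leave the number within the scatter. Nothing measured here gives a reason for either step.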